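Chloro in Place of Methoxy: What Compound 3 Might Give

The source may hold more compounds than are shown below. What is called first, only, known or untested is meant among the compounds shown, and "the series" means these compounds.

compound 1 `Cc1cc(Cl)cc(C(=O)Nc2nn[nH]n2)n1`: 100%
compound 2 `COc1cccc(C(=O)Nc2nn[nH]n2)n1`: 58%

In a functional assay on the whole organism for inhibition, with Rattus norvegicus as the target, at a dose of 10 mg/kg by the oral route (on this read-out lower numbers stand for a weaker effect and higher numbers for a stronger effect at the one dose given), compound 1 gives 100% and compound 2 gives 58%, the lower of the two numbers, with compound 1 standing higher by a gap beyond the usual scatter. Compound 3 `O=C(Nc1nn[nH]n1)c1cccc(Cl)n1` differs from compound 2 in a single place: chloro in place of methoxy on an aromatic carbon. Among the measured compounds shown here, no measured pair shows this exact change, so its size is unknown. A modest rise is expected, because compound 1, which also carries a chloro group, gives 100%. Compound 3 is estimated at 72%, within 45% to 95%. The expected step is a number 14 percentage points higher from compound 2 to compound 3 (beyond the scatter).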

Compound 3, a percentage reported as inhibition, in the whole organism at one dose (the size of the read-out at that dose, not a potency): 13%
Compound 3: middle estimate off by 59 percentage points, on the high side; measured number below the stated range.
By their numbers in this assay, from the lowest: compound 3; then compound 2; then compound 1.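

In this assay chloro in place of methoxy, on an aromatic carbon next to the ring nitrogen, gives a number 45 percentage points lower from compound 2 to compound 3 (beyond the scatter) and so shows that this position is far from indifferent to what it carries. A single exchange here is enough to take away much of the effect seen with methoxy. Nothing measured here explains this large step.

The compounds shown leave open how an amine or a longer chain such as ethoxy would fare at this same place. They also leave open whether any group there can go beyond methoxy.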